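The source may hold more compounds than are shown below. What is called first, only, known or untested is meant among the compounds shown, and "the series" means these compounds.

For the measured compounds named here, compound 2, `CCCCCCN1C(=O)[C@H](Cc2ccc(-c3cccc(CN(CCCC)C(=O)NC)c3)cc2)N(C)C(=O)[C@@H]1C`, gives 85% in a functional assay on cells for agonist activity at follicle-stimulating hormone receptor (Homo sapiens), read by cAMP accumulation (on this read-out lower numbers stand for smaller maximal responses and higher numbers for larger maximal responses), the higher of the two numbers measured so far. Compound 1, `CCCCCCCCN1C(=O)[C@H](Cc2ccc(-c3cccc(CN(CCCC)C(=O)OC)c3)cc2)N(C)C(=O)[C@@H]1C`, gives 49% in this assay, a gap beyond the usual scatter. Compound 3, `CCCCCCCCN1C(=O)[C@H](Cc2ccc(-c3cccc(CN(CCCC)C(=O)NC)c3)cc2)N(C)C(=O)[C@@H]1C`, is the next step from compound 2: ethyl in place of hydrogen on a saturated chain carbon, six bonds along the chain from an amide-type nitrogen in a ring. Going by the values given here, no measured pair shows this change on its own, so its effect is not known. Compound 3 also shares its longer chain with compound 1, whose lower value counsels caution. The step from compound 2 to compound 3 is therefore expected to be a moderate drop, a number 20 percentage points lower from compound 2 to compound 3 (beyond the scatter). Compound 3 is estimated at 65%, within a range from 40% to 90%.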

Compound 3, largest response reached (reported as efficacy), in percent of the reference or control that the assay uses: 72%
For compound 3 the middle estimate is 7 percentage points below the measured one, within the range that was stated.
By their numbers in this assay, from the lowest: compound 1; then compound 3; then compound 2.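

Ethyl in place of hydrogen on this saturated chain carbon gives, in this assay, a number 13 percentage points lower from compound 2 to compound 3 (beyond the scatter), so this change alone lowers the maximal response modestly. Methylamino in place of methoxy on the carbonyl carbon gives a number 23 percentage points higher from compound 1 to compound 3 (beyond the scatter). Each change can now be read alone, and the two point in opposite directions. As far as these compounds go, whether a still longer chain, or an amine at the chain end, would lower the response further remains open, as does the outcome of ethylamino or dimethylamino on that carbonyl carbon. No evidence is available to explain either step.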